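Cyclopropenyl purine series: cytotoxicity toward fibroblasts

This account rests on a few compounds, and the source may have more. Where it says the series, first, only, none or still open, it means among the compounds named here.

Measured compounds:
compound 1 `CCCCCOc1nc(N)nc2c1ncn2/C=C1/CC1(CO)CO`, 259000 nM
compound 2 `CCCCCCCCSc1nc(N)nc2c1ncn2/C=C1/CC1(CO)CO`, > 300000 nM

Compound 2 in an ADME assay on HFF cells (Homo sapiens) for cytotoxicity, with a stated time of 8 days (on this read-out higher numbers stand for lower toxicity in this test and lower numbers for higher toxicity in this test), gives only a limit, > 300000 nM; the value is a limit of the assay, not a number (the limit of > 300000 nM in this assay, at which 1 of the 2 values shown sits). Compound 1 gives 259000 nM in this assay. For the measured compounds named here, the only measured step, an at least 1.1-fold higher number from compound 1 to compound 2 (0.06 log units; that floor lies within the scatter), has its floor within the scatter. Compound 3 `C=CCOc1nc(N)nc2c1ncn2/C=C1/CC1(CO)CO` carries allyloxy in place of octylsulfanyl on an aromatic carbon, moving back toward a short oxygen-linked chain like that of compound 1. No step beyond the scatter is expected; compound 3 is estimated at 280000 nM, range 120000 nM to 600000 nM, a step of an at least 1.0-fold lower number from compound 2 to compound 3 (0.02 log units; that floor lies within the scatter) that is itself expected rather than measured.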

Compound 3, half-maximal cytotoxic concentration: > 300000 nM
Compound 3 gave a limit, no number; the forecaster's own chance of this, stated with the estimate: 45%; at least 1.0-fold (0.02 log units) between middle value and limit.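

In this assay, allyloxy at this position, on an aromatic carbon next to the ring nitrogen, gives a limit, as octylsulfanyl does: the limit of > 300000 nM in this assay, at which 2 of the 3 values shown sit. Against compound 1, vinyl in place of butyl gives an at least 1.1-fold higher number from compound 1 to compound 3 (0.06 log units; that floor lies within the scatter), so this change shows no separation beyond the scatter. The step between the two limit compounds cannot be read.

Open, going by these compounds, is whether an amine or a carboxylic acid at this position would give a lower number in this assay, beyond the scatter from compound 1. On these data alone, how far compound 2 and compound 3 lie past the limit also stays open.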